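A Fluorine Added Beside the Anilino Nitrogen of the Core

This account rests on a few compounds, and the source may have more. Where it says the series, first, only, none or still open, it means among the compounds named here.

Compound 1, `O=C(CSc1nc(Nc2ccccc2)c2ccccc2n1)Nc1cccc(F)c1`, carries a fluoro group on the outer aromatic ring of its amide. In a functional assay on MDA-MB-231 cells (Homo sapiens) for inhibition, read by MTT assay, with a stated time of 72 h (on this read-out higher numbers stand for weaker inhibition and lower numbers for stronger inhibition), compound 1 reaches only > 50000 nM, a limit of the assay and not a number. Compound 2, `C=CC(=O)Nc1cccc(NC(=O)CSc2nc(Nc3ccccc3)c3ccccc3n2)c1`, puts a (vinylcarbonyl)amino group where that fluoro stood, and compound 2 gives 10200 nM. Among the measured compounds shown here, the single measured step, an at least 4.9-fold lower number from compound 1 to compound 2 (0.69 log units; beyond the scatter), begins from the limit of > 50000 nM in this assay, at which 1 of the 2 values shown sits, and is therefore itself only a floor on the change. For the measured compounds named here, compound 2 holds the sole real number in this assay; the other value is a limit.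

Compound 3, `C=CC(=O)Nc1cccc(NC(=O)CSc2nc(Nc3ccccc3F)c3ccccc3n2)c1`, keeps all of compound 2 and adds one change: fluoro in place of hydrogen on an aromatic carbon. It sits on an aromatic carbon of a six-membered aromatic ring of carbon only, ortho to a large group, so anilino becomes (2-fluorophenyl)amino. The measured step concerns a different ring and a different group, so it does not bear on this change. Compound 3 is thus expected to show a 1.0-fold lower number from compound 2 to compound 3 (0.01 log units; within the scatter), nothing beyond the scatter. Compound 3 is estimated at 10000 nM, between 4000 nM and 25000 nM.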

Compound 3, half-maximal inhibitory concentration: 18700 nM
Compound 3: middle estimate off by 1.9-fold (0.27 log units), on the low side; the range from low to high includes it.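

Replacing hydrogen with fluoro on an aromatic carbon, ortho to a large group, turns anilino into (2-fluorophenyl)amino, and in this assay this gives a 1.8-fold higher number from compound 2 to compound 3 (0.26 log units; within the scatter) for this single change to the core. Among the compounds shown here, the earlier step altered the outer ring of the amide and started from a limit, whereas this one joins two real numbers and gives the first reading on the anilino ring: at this position, the fluoro group leaves the two compounds within the normal spread of repeated measurements. Nothing among the measurements shown explains this outcome.

As far as these compounds go, it remains open whether a different group at this same position, such as chloro, methoxy, trifluoromethyl or an amine, would move the read-out beyond that spread in either direction. From the compounds shown here alone, it also remains open whether fluoro on another carbon of the anilino ring would behave as it does here, since a single substituted compound cannot describe the whole ring.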